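Thiazolyl hydrazones and tolerance by mouse macrophages

The source may hold more compounds than are shown below. What is called first, only, known or untested is meant among the compounds shown, and "the series" means these compounds.

Compound 1, `C/C(=N\Nc1nc(C)c(C)s1)c1ccc(Cl)c(Cl)c1`: in an ADME assay on J774 cells (Mus musculus) for cytotoxicity, read by resazurin assay, with a stated time of 72 h (a higher number here means that more compound is tolerated, a lower number that less compound is tolerated), compound 1 gives 41800 nM.
Compound 2, `C/C(=N\Nc1nc(-c2ccccn2)cs1)c1ccc(Cl)c(Cl)c1`: in this assay compound 2 gives 10100 nM.
Compound 3, `C/C(=N\Nc1nc(-c2cccc([N+](=O)[O-])c2)cs1)c1ccc(Cl)c(Cl)c1`: in this assay compound 3 reaches only a limit, > 50000 nM.

Among the two numbers measured, compound 2 stands lowest; the nearest is compound 1, whose number is higher by a gap that lies beyond the usual scatter of this kind of measurement. Compound 3 sits at the limit of > 50000 nM in this assay, at which 1 of the 3 values shown sits, so for it only a limit and no number is known.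

Compound 4, `COc1ccc(-c2csc(N/N=C(\C)c3ccc(Cl)c(Cl)c3)n2)cc1`, has not yet been measured in this assay. It differs from compound 2 in a single place:

4-methoxyphenyl in place of pyridin-2-yl on an aromatic carbon

Within the data shown here, no step between two measured compounds matches this change, so its size cannot be read from the measured pairs. The two compounds that already carry a six-membered aromatic ring at this place, compound 2 and compound 3, span the whole range from the lowest number to the limit. In this assay the step is expected to be a 2.5-fold higher number from compound 2 to compound 4 (0.39 log units; beyond the scatter), upward and modestly beyond the scatter, with a real chance that only a limit is reported. Compound 4 is therefore estimated at 25000 nM, within a range from 8000 nM to 60000 nM.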

Compound 4, half-maximal cytotoxic concentration: > 50000 nM
Compound 4 gave a limit, no number; the forecaster's own chance of this, stated with the estimate: 25%; middle value at least 2.0-fold (0.30 log units) away from the limit.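

In this assay, among these compounds, placing 4-methoxyphenyl instead of pyridin-2-yl on this aromatic carbon gives an at least 4.9-fold higher number from compound 2 to compound 4 (0.69 log units; beyond the scatter), the first step at this position that can be read, and it shows that the position responds to the exchange of one six-membered aromatic ring for another. Compound 4 gives a limit and not a number, > 50000 nM, so the step has a lower bound but no known full size: the limit of > 50000 nM in this assay, at which 2 of the 4 values shown sit. Compound 2, whose ring holds a hetero atom, now stands apart from compound 3 and compound 4, which both carry a ring of carbon only, both stop at the limit and so cannot be ordered against each other.

Going by these compounds, with so few compounds, the pattern rests on a single pyridin-2-yl example, and it stays open whether the lower number in compound 2 goes with that ring nitrogen or with the absence of a further group on the ring. An unsubstituted phenyl, a pyridin-3-yl ring, or a phenyl ring bearing an amine or a carboxylic acid at this place would help to separate these readings.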